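Amide to urea switch: growth inhibition notes

This account rests on a few compounds, and the source may have more. Where it says the series, first, only, none or still open, it means among the compounds named here.

Measured compounds:
compound 1 `O=C(Nc1cccc(-n2cc(-c3ccncc3)c(-c3ccc(Cl)c(O)c3)n2)c1)Nc1cccc(C(F)(F)F)c1` — > 32500 nM
compound 2 `COc1cc(-c2nn(-c3cccc(NC(=O)c4cccc(C(F)(F)F)c4)c3)cc2-c2ccncc2)ccc1Cl` — > 50000 nM

Both values shown are limits of a functional assay on KM12 cells (Homo sapiens) for inhibition, read by sulforhodamine B assay, with a stated time of 48 h (a higher number here means a weaker inhibitor of growth, a lower number a stronger inhibitor of growth), and not numbers. Compound 1 reaches only the limit > 32500 nM (the limit of > 32500 nM in this assay, at which 1 of the 2 values shown sits). Compound 2 reaches only the limit > 50000 nM (the limit of > 50000 nM in this assay, at which 1 of the 2 values shown sits). Among the compounds with values here, compound 2 therefore stands at a limit with no measured number; the one further value shown is a limit as well.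

Compound 3 `COc1cc(-c2nn(-c3cccc(NC(=O)Nc4cccc(C(F)(F)F)c4)c3)cc2-c2ccncc2)ccc1Cl` differs from compound 2 by (3-(trifluoromethyl)phenyl)amino in place of 3-(trifluoromethyl)phenyl on a carbonyl carbon. Within the data shown here, no step between measured compounds is available to size this change. Compound 1 carries the same urea and sits at a limit. On that basis the step of a number no higher from compound 2 to compound 3 (the limit leaves the size open) is expected to be none beyond the scatter. Compound 3 is estimated at 50000 nM, within 15000 nM to 100000 nM, most likely reported again only as a limit in this assay.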

Compound 3, concentration for total growth inhibition: 1980 nM
Estimate against measurement, compound 3: 25-fold (1.40 log units) above; the whole stated range lies above it.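

In this assay, (3-(trifluoromethyl)phenyl)amino in place of 3-(trifluoromethyl)phenyl on the carbonyl carbon gives an at least 25-fold lower number from compound 2 to compound 3 (1.40 log units; beyond the scatter), and compound 3 is the first of the series shown with a measured number rather than a limit. The urea alone does not account for this, since compound 1 carries the same urea and methyl in place of hydrogen on an oxygen on an aromatic ring gives an at least 16-fold lower number from compound 1 to compound 3 (1.21 log units; beyond the scatter). Compound 2 is a limit and not a number, so the amide to urea step is a minimum only: the limit of > 50000 nM in this assay, at which 1 of the 3 values shown sits.

As far as these compounds go, it remains open how far the methyl on that oxygen can be varied, for example to an ethyl. Also open, from the compounds shown here alone, is whether a carboxylic acid in place of the trifluoromethyl keeps a measured number in this assay.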